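What a benzyl group may do to compound 2

A few compounds are considered here, and "the series" means these few. Any claim that something is new, unique, unknown or untested is made for them only; others in the source may bear on it.

In an ADME assay on S9 fraction from liver (Homo sapiens) for metabolic stability, read by LC-MS, with a stated time of 15 min, tested at 1 uM (a lower number here means that less of the compound is left, a higher number that more of the compound is left), compound 2 `CC(=O)Nc1onc(-c2ccc(F)cc2)c1-c1ccncc1` gives 82.5%, the highest of the three numbers and clearly beyond the scatter from the other two. Compound 4 `O=C(CCc1ccccc1)Nc1onc(-c2ccc(F)cc2)c1-c1ccncc1` differs from it in one place: benzyl in place of hydrogen on a saturated chain carbon bound to a carbonyl carbon. Within the data shown here, no measured pair isolates this change, so the expectation rests loosely on compound 1 `Fc1ccc(-c2n[nH]c(CCCc3ccccc3)c2-c2ccncc2)cc1` at 50.3% and compound 3 `O=C(Nc1onc(Nc2ccc(F)cc2)c1-c1ccncc1)c1ccccc1` at 10.9%, which differ from compound 2 in other ways but, like compound 4, carry an additional carbon-only aromatic ring. A drop beyond the scatter is expected, estimated as a number 37.5 percentage points lower from compound 2 to compound 4 (beyond the scatter). The estimate for compound 4 is 45%, with an expected range of 20% to 70%.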

Compound 4, percent of the compound remaining: 27.9%
Beside the measured number, compound 4's estimate is 17.1 percentage points above it, within the range that was stated.
By their numbers in this assay, from the lowest: compound 3; then compound 4; then compound 1; then compound 2.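

Benzyl in place of hydrogen on a saturated chain carbon bound to a carbonyl carbon gives a number 54.6 percentage points lower from compound 2 to compound 4 (beyond the scatter) in this assay, the first reading of this change with the rest of the molecule held fixed. This single change, also readable as methyl to phenethyl, is thus enough to leave far less of the compound. Nothing available explains the fall.

The compounds shown leave open whether the carbon-only ring or the extra chain length carries the drop. A plain longer chain, or an amine in place of benzyl at this carbon, would help tell these apart.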